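This account rests on a few compounds, and the source may have more. Where it says the series, first, only, none or still open, it means among the compounds named here.

Compound 1 `CC(=O)N(C)C(C)C#CCn1ccnc1` gives 3 mg/kg in a functional assay on the whole organism for agonist activity, with Mus musculus as the target; on this read-out lower numbers stand for an effect already at smaller amounts and higher numbers for an effect only at larger amounts of compound. Compound 2 `CC(=O)N(C)C(C)C#CCn1ccnc1C` shows only a limit of the assay in this assay, > 100 mg/kg. The change methyl in place of hydrogen on an aromatic carbon thus brings an at least 33-fold higher number from compound 1 to compound 2 (1.52 log units; beyond the scatter). Compound 3 `CC(=O)NCC#CCn1ccnc1` likewise shows only a limit, > 100 mg/kg; how its core differs from the core of compound 1 is not broken down here. Compound 4 `CC(=O)NCC#CCn1cncc1C` arises from compound 3 by the same kind of change, (methyl in place of hydrogen on an aromatic carbon), though the place is not identical: in compound 2 the methyl sits between two ring nitrogen atoms, next to the ring atom that bears a large group, whereas in compound 4 it sits next to the ring nitrogen, two ring bonds from the ring nitrogen. Since compound 3 already sits at the limit of > 100 mg/kg in this assay, at which 2 of the 3 values shown sit, and the earlier methyl gave an at least 33-fold higher number from compound 1 to compound 2 (1.52 log units; beyond the scatter), compound 4 is expected to remain at or beyond that limit, an estimated step that the limit leaves unreadable from compound 3 to compound 4. Compound 4 is estimated at 300 mg/kg, between 60 mg/kg and 2000 mg/kg.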

Compound 4, dose for half-maximal effect: 66 mg/kg
For compound 4 the middle estimate is 4.5-fold (0.66 log units) above the measured one; the range from low to high includes it.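

Methyl in place of hydrogen on an aromatic carbon does not carry from one core to the other as a step of one size in this assay: the same change on two cores in this assay, an at least 33-fold higher number (1.52 log units; beyond the scatter) from compound 1 to compound 2 and an at least 1.5-fold lower number (0.18 log units; that floor lies within the scatter) from compound 3 to compound 4, at least 50-fold (1.70 log units) apart, beyond the scatter of two such steps. The new step brings an at least 1.5-fold lower number from compound 3 to compound 4 (0.18 log units; that floor lies within the scatter), and as it starts from a limit it gives only a floor, not a size. The methyl also stands at a different place on the ring in compound 4 than in compound 2, and these compounds do not separate the effect of place from that of core.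

On these data alone, it remains open how a methyl at the place it holds in compound 4 acts on the core of compound 1. As far as these compounds go, an ethyl or a chlorine at either ring carbon is also open.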